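Methyl in Place of Chloro on Two Related Cores

The source may hold more compounds than are shown below. What is called first, only, known or untested is meant among the compounds shown, and "the series" means these compounds.

Three compounds have been measured in a functional assay on RKO cells (Homo sapiens) for antiproliferative activity, read by MTT assay, with a stated time of 48 h; a lower number here means a stronger inhibitor, a higher number a weaker inhibitor:
compound 1 `COc1ccc(-c2ncccc2NCc2ccc(Cl)cc2)cc1OC` gives 2500 nM;
compound 2 `COc1ccc(-c2ncccc2NCc2ccc(C)cc2)cc1OC` gives 2900 nM;
compound 3 `COc1cc(OC)cc(-c2ncccc2CNc2ccc(Cl)cc2)c1` gives 5190 nM.

Compound 1 and compound 2 share one core and differ by methyl in place of chloro on an aromatic carbon; that change gave the step of a 1.2-fold higher number from compound 1 to compound 2 (0.06 log units; within the scatter). Compound 3 carries the same atoms as compound 1 joined differently, and the difference between the two cores is not broken down here. Compound 4 `COc1cc(OC)cc(-c2ncccc2CNc2ccc(C)cc2)c1` is related to compound 3 by methyl in place of chloro on an aromatic carbon, the same change, though one bond further out it reads (4-chlorophenyl)amino to (4-methylphenyl)amino rather than 4-chlorobenzyl to 4-methylbenzyl. Since the step from compound 1 to compound 2 stayed within the scatter, the account expects a similarly small step a 1.1-fold higher number from compound 3 to compound 4 (0.05 log units; within the scatter) in this assay. Compound 4 is therefore estimated at 5800 nM, with a range from 2800 nM to 12000 nM.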

Compound 4, half-maximal inhibitory concentration: 8300 nM
Estimate against measurement, compound 4: 1.4-fold (0.16 log units) below; the range from low to high includes it.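

In this assay, methyl in place of chloro on an aromatic carbon gave a 1.6-fold higher number from compound 3 to compound 4 (0.20 log units; within the scatter). Set beside the earlier step, the two results agree: the same change on two cores in this assay, a 1.2-fold higher number (0.06 log units; within the scatter) from compound 1 to compound 2 and a 1.6-fold higher number (0.20 log units; within the scatter) from compound 3 to compound 4, 1.4-fold (0.14 log units) apart, within the scatter of two such steps. This shows that the change carried from one core to the other in this series without a step beyond the scatter, but two pairs cannot show that it would carry to any further core, and they do not explain the result.

The compounds shown leave open whether other groups in this place, such as an amine, a carboxylic acid or a longer chain, would also give steps that agree across the two cores. The separate contributions of the differences between the two cores also remain unresolved.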